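Isobutyl for 4-(tert-butyl)phenyl on the core of compound 1

The source may report more compounds than this note shows. Statements on the series, on what has been measured and on what is new or still open speak of the compounds shown alone.

Compound 1 `COc1cccc(CNCCCNc2ccnc3cc(-c4ccc(C(C)(C)C)cc4)ccc23)c1O` is the starting point. In a physicochemical assay for solubility, with a stated time of 18 h, at pH 7.4 (on this read-out lower numbers stand for lower solubility and higher numbers for higher solubility), compound 1 gives 32000 nM. Compound 3 `CC(C)(C)c1ccc(-c2ccc3c(NCCCNCc4ccco4)ccnc3c2)cc1` gives 32000 nM, and compound 2 `Fc1ccc(Cc2ccc3c(NCCCNCc4ccco4)ccnc3c2)cc1` gives 4200 nM. Compound 1 stands level with compound 3, the two together the highest of the three numbers; the step of no change at the digits printed from compound 1 to compound 3 (within the scatter) shows that exchange leaves the read-out unmoved. Against compound 2 the gap is a 7.6-fold higher number from compound 2 to compound 3 (0.88 log units; beyond the scatter), so compound 1 sits well above compound 2.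

Compound 4 `COc1cccc(CNCCCNc2ccnc3cc(CC(C)C)ccc23)c1O` differs from compound 1 in one place: isobutyl in place of 4-(tert-butyl)phenyl on an aromatic carbon. Among the compounds with values here, no measured step covers this exchange. Within the data shown here, the only step at the same aromatic carbon is a 7.6-fold higher number from compound 2 to compound 3 (0.88 log units; beyond the scatter), which concerns a different pair of groups and offers no direct guide. With nothing to set the direction, the expectation for compound 4 is a number close to that of compound 1, with the uncertainty tilted upward; the expected step is a 1.3-fold higher number from compound 1 to compound 4 (0.10 log units; within the scatter). Compound 4 is therefore expected at 40000 nM in this assay, within a range of 12000 nM to 130000 nM.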

Compound 4, solubility: 4200 nM
The estimate for compound 4 lay 9.5-fold (0.98 log units) above the measured number; measured number outside the range, below it.
By their numbers in this assay, from the lowest: compounds 2 and 4 (each within the scatter of the next); then compounds 1 and 3 (each within the scatter of the next).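

Working from this assay, the aromatic carbon now carries a step with the 2-hydroxy-3-methoxyphenyl side chain in place: a 7.6-fold lower number from compound 1 to compound 4 (0.88 log units; beyond the scatter) on going to isobutyl. Set beside a 7.6-fold higher number from compound 2 to compound 3 (0.88 log units; beyond the scatter) with the furan-2-yl side chain, this gives two pairs at this position, and in both the compound carrying 4-(tert-butyl)phenyl has the higher number, whether the partner is isobutyl or 4-fluorobenzyl. Nothing measured here accounts for the step.

From the compounds shown here alone, it remains open whether the higher number goes with the aromatic ring of 4-(tert-butyl)phenyl or with the size of the group, and a plain phenyl or a cyclohexyl on this aromatic carbon would separate the two. Also open, going by these compounds, is whether isobutyl gives the same result with the furan-2-yl side chain.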